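A few compounds are considered here, and "the series" means these few. Any claim that something is new, unique, unknown or untested is made for them only; others in the source may bear on it.

Working notes on the series. In a functional assay on HL-60 cells (Homo sapiens) for antiproliferative activity, read by MTT assay, with a stated time of 24 h (a higher number here means a weaker inhibitor, a lower number a stronger inhibitor), compound 2 (`CCCCNC(=O)COc1ccc(C(=O)c2c(CCCC)oc3ccccc23)cc1`) stands at > 50000 nM, which is a limit and not a number. Compound 3 (`CCCCc1oc2ccccc2c1C(=O)c1ccc(OCC(=O)N2CCN(C(=O)OC(C)(C)C)CC2)cc1`) gives > 50000 nM, also a limit. The set thus shows (the limit of > 50000 nM in this assay, at which 2 of the 3 values shown sit). Compound 1 (`CCCCc1oc2ccccc2c1C(=O)c1ccc(OCC(=O)NC(C)C)cc1`) gives a true number, 360 nM. Going by the values given here, the one measured step at this amide-type nitrogen is an at least 130-fold higher number from compound 1 to compound 2 (2.14 log units; beyond the scatter), with butyl in place of isopropyl. Compound 4 (`CCCCc1oc2ccccc2c1C(=O)c1ccc(OCC(=O)Nc2ccccc2)cc1`) changes the same place, with phenyl in place of butyl on an amide-type nitrogen. That single large step shows this nitrogen's substituent can matter, so a sizeable move in this assay towards a lower number is expected, though another limit remains possible. The expected change is an at least 5.0-fold lower number from compound 2 to compound 4 (0.69 log units; beyond the scatter). Compound 4 is estimated at 10000 nM, within an expected range of 500 nM to 50000 nM.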

Compound 4, half-maximal inhibitory concentration: > 50000 nM
Compound 4 was reported as a limit; the forecaster's own chance of this, stated with the estimate: 45%; middle value at least 5.0-fold (0.69 log units) away from the limit.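

A second, ring-bearing group on this amide-type nitrogen also fails to keep the activity of compound 1: in this assay the change of isopropyl to phenyl gives an at least 130-fold higher number from compound 1 to compound 4 (2.14 log units; beyond the scatter). The step between butyl and phenyl cannot be read, as compound 2 and compound 4 both stand at a limit. Of the compounds shown, only compound 1 gives a true number, and the others stand at one limit: the limit of > 50000 nM in this assay, at which 3 of the 4 values shown sit.

Open, as far as these compounds go, is whether ethyl, cyclopropyl or tert-butyl on this nitrogen would give a true number. Also open, from the compounds shown here alone, is whether a chain ending in an amine or a carboxylic acid would do so.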